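Swapping a Nitrile for an Alkyne on the Carbinol Arm

A few compounds are considered here, and "the series" means these few. Any claim that something is new, unique, unknown or untested is made for them only; others in the source may bear on it.

Compound 1 `CC#C[C@H]1CN(S(=O)(=O)c2ccc(N)nc2)CCN1c1ccc(C(O)(CC#N)C(F)(F)F)cc1` has been measured in an assay on cells (Hepatocyte) for inhibition of glucokinase regulatory protein (Mus musculus), with stated times of 20 min and 40 min (on this read-out lower numbers stand for an effect already at smaller amounts and higher numbers for an effect only at larger amounts of compound), and gives 219 nM. Among the two values shown, this is the only one that is a number. Among the measured compounds shown here, compound 2 `CC#C[C@H]1CN(S(=O)(=O)c2ccc(N)nc2)CCN1c1ncc(C(O)(C(F)(F)F)C(F)(F)F)s1` in this assay reaches only > 12500 nM, which is a limit of the assay rather than a measured value, so it offers no step against which compound 1 can be placed. Compound 3 `C#CCC(O)(c1ccc(N2CCN(S(=O)(=O)c3ccc(N)nc3)C[C@@H]2C#CC)cc1)C(F)(F)F` has not yet been measured in this assay. It differs from compound 1 in one place: ethynyl in place of cyano on a saturated chain carbon, two bonds along the chain from an aromatic carbon and an oxygen on a saturated carbon. As counted, the group that leaves and the group that enters are alike in size, and the cyano carries a hydrogen-bond acceptor where the ethynyl carries none. For the measured compounds named here, no measured pair in this set shows what such an exchange does, so the expectation rests on the closeness of the two groups alone. The step from compound 1 to compound 3 is expected to be small, a 1.4-fold higher number from compound 1 to compound 3 (0.14 log units; within the scatter), within or only slightly beyond the usual scatter, in either direction. Compound 3 is therefore expected to give about 300 nM, with a range from 100 nM to 1000 nM.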

Compound 3, half-maximal effective concentration: 130 nM
Beside the measured number, compound 3's estimate is 2.3-fold (0.36 log units) above it, within the range that was stated.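

Among the compounds shown here, the exchange of cyano for ethynyl on a saturated chain carbon, two bonds along the chain from an aromatic carbon and an oxygen on a saturated carbon, is the first single change in this set that can be read in numbers: in this assay it amounts to a 1.7-fold lower number from compound 1 to compound 3 (0.23 log units; within the scatter) and the two compounds cannot be told apart on this read-out. The hydrogen-bond acceptor counted on the cyano is absent from the ethynyl, yet the values stay within what repeated measurements of the same compound would scatter over, so the nitrile nitrogen is not needed at this position for an effect at these amounts of compound. Nothing measured here tells why the two groups read alike.

The compounds shown leave open how much more this position accepts, for example whether a longer chain, an amine or a carboxylic acid in place of the cyano would hold the number. They also leave open whether the same exchange would read alike on a different core, or in a read-out other than this assay as used here.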